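This account rests on a few compounds, and the source may have more. Where it says the series, first, only, none or still open, it means among the compounds named here.

Compound 1, `C[C@H](N)C(=O)NCc1cccnc1Oc1ccc(F)cc1F`, and compound 2, `C[C@@H](N)C(=O)NCc1cccnc1Oc1ccc(F)cc1F`, are built on the same core and differ only in the configuration as drawn at the chain carbon that carries the amine and the methyl. In an assay on isolated protein for inhibition of protein arginine N-methyltransferase 6 (Homo sapiens) (a higher number here means a weaker inhibitor, a lower number a stronger inhibitor), compound 1 gives 14000 nM. In this assay compound 2 is reported as "not active" (no number reported), so no number stands for it, and the contrast with compound 1 rests on (the fact that compounds 1 and 2 differ only in the configuration as drawn). Within the data shown here, compound 2 therefore stands at the weak end of what the numbers show, with only the single figure for compound 1 above it as a point of reference.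

Compound 3, `NCC(=O)NCc1cccnc1Oc1ccc(F)cc1F`, removes that stereocentre: the change is hydrogen in place of methyl on a saturated chain carbon bound to an amine nitrogen and a carbonyl carbon. Compound 2 carries no number. The size of the step in this assay therefore cannot be placed against a measured starting point. The expectation is that compound 3 stays weak, somewhere near the level of compound 1 or beyond it, and that a limit rather than a number is a real possibility. Compound 3 is estimated at 20000 nM, within a range from 5000 nM to 100000 nM.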

Compound 3, half-maximal inhibitory concentration: "not active" (no number reported)
No number was reported for compound 3, and the estimate cannot be compared.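

In this assay, among these compounds, compound 2 is reported as "not active" (no number reported) and compound 3 as "not active" (no number reported), so neither has a number and no step between them can be read. The compounds shown leave open how far compound 2 and compound 3 lie from compound 1, and whether hydrogen in place of methyl changes inhibition at all.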